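Carbamoyl in place of hydroxy on the distal ring

The source may report more compounds than this note shows. Statements on the series, on what has been measured and on what is new or still open speak of the compounds shown alone.

Measured compounds:
- compound 1, `CC(=O)NCCN(C)c1cccc(OCCCCN)c1`: "not determined" (no result reported)
- compound 2, `CC(=O)NCCN(C)c1cccc(OCCCCCCNC(=O)Oc2cccc(-c3ccccc3)c2)c1`: 1.34 nM
- compound 3, `CC(=O)NCCN(C)c1cccc(OCCCCCCNC(=O)Oc2cccc(-c3cccc(O)c3)c2)c1`: 0.36 nM

The study measures inhibition in an assay (brain, strain Wistar) for inhibition of Fatty-acid amide hydrolase 1 (Rattus norvegicus), read by scintillation counting, with a stated time of 30 min; on this read-out lower numbers stand for stronger inhibition and higher numbers for weaker inhibition. Compound 1 carries "not determined" (no result reported) in this assay. Compound 2 gives 1.34 nM, and compound 3 gives 0.36 nM. For the measured compounds named here, compound 3 therefore holds the lowest of the two numbers; the only measured step, a 3.7-fold lower number from compound 2 to compound 3 (0.57 log units; beyond the scatter), separates it from compound 2, and it lies beyond the scatter.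

Compound 4, `CC(=O)NCCN(C)c1cccc(OCCCCCCNC(=O)Oc2cccc(-c3cccc(C(N)=O)c3)c2)c1`, differs from compound 3 in one place: carbamoyl in place of hydroxy on an aromatic carbon. The step from compound 2 to compound 3 is the only one that bears on this change, since it concerns the same position on the same ring, where a hydroxy group gave a modest gain. The carbamoyl group that now enters also brings one donor and one acceptor, so a similar or somewhat weaker effect is expected, and the step of a 1.1-fold higher number from compound 3 to compound 4 (0.05 log units; within the scatter) is estimated to stay within or near the scatter. Compound 4 is therefore expected to give about 0.4 nM, between 0.12 nM and 1.4 nM.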

Compound 4, half-maximal inhibitory concentration: 0.43 nM
Beside the measured number, compound 4's estimate is 1.1-fold (0.03 log units) below it; the measured number falls inside the stated range.
By their numbers in this assay, from the lowest: compounds 3 and 4 (each within the scatter of the next); then compound 2.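

In this assay the change from hydroxy to carbamoyl gives a 1.2-fold higher number from compound 3 to compound 4 (0.08 log units; within the scatter) and so leaves the number unmoved within the scatter, although the group that enters is larger by the heavy atoms counted for it. Set against the unsubstituted ring, the carbamoyl group gives a 3.1-fold lower number from compound 2 to compound 4 (0.49 log units; beyond the scatter) in a step close to a 3.7-fold lower number from compound 2 to compound 3 (0.57 log units; beyond the scatter) and so shows that the gain at this place is not confined to hydroxy, since two different groups now give it. Nothing available accounts for this likeness between the two groups.

The compounds shown leave open whether an amine, a carboxylic acid or a methoxy group on the same aromatic carbon would read with compound 3 and compound 4 or with compound 2. They also leave open whether a carbamoyl group would give the same number on another carbon of this ring.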